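This account rests on a few compounds, and the source may have more. Where it says the series, first, only, none or still open, it means among the compounds named here.

In a functional assay on HeLa cells (Homo sapiens) for antiproliferative activity, read by MTT assay, with a stated time of 48 h (a lower number here means a stronger inhibitor, a higher number a weaker inhibitor), compound 1 (`O=C(CNC(=O)c1cc2ccccc2cn1)OCc1ccccc1`) gives 195 nM and compound 2 (`O=C(C[C@H](NC(=O)c1cc2ccccc2cn1)C(=O)OCc1ccccc1)OCc1ccccc1`) gives 411 nM as the higher of the two numbers, which makes compound 2 the weaker inhibitor. The move to compound 3 (`CC[C@@H](C)[C@H](NC(=O)c1cc2ccccc2cn1)C(=O)OCc1ccccc1`) is sec-butyl in place of (benzyloxycarbonyl)methyl on a saturated chain carbon bound to an amide-type nitrogen and a carbonyl carbon and puts sec-butyl in place of (benzyloxycarbonyl)methyl on a saturated chain carbon bound to an amide-type nitrogen and a carbonyl carbon. Going by the values given here, one measured step bears on this: a 2.1-fold higher number from compound 1 to compound 2 (0.32 log units; beyond the scatter) is the modest step that goes with (benzyloxycarbonyl)methyl in place of hydrogen at that same place. Among the compounds with values here, no measured compound carries sec-butyl, so this single step is a limited guide. Going by a 2.1-fold higher number from compound 1 to compound 2 (0.32 log units; beyond the scatter) for compound 2, a small step toward a lower number is expected in this assay and it may stay within the scatter. Compound 3 is expected at 280 nM with an estimated range from 100 nM to 750 nM in this read-out. The estimate means a 1.5-fold lower number from compound 2 to compound 3 (0.17 log units; within the scatter) as the expected step.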

Compound 3, half-maximal inhibitory concentration: 185 nM
For compound 3 the middle estimate is 1.5-fold (0.18 log units) above the measured one; measured number inside the range.
By their numbers in this assay, from the lowest: compounds 3 and 1 (each within the scatter of the next); then compound 2.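

In this assay, the place on a saturated chain carbon bound to an amide-type nitrogen and a carbonyl carbon now has a second substituent, and sec-butyl in place of hydrogen gives a 1.1-fold lower number from compound 1 to compound 3 (0.02 log units; within the scatter) with no separation between the two. Sec-butyl in place of (benzyloxycarbonyl)methyl gives a 2.2-fold lower number from compound 2 to compound 3 (0.35 log units; beyond the scatter) in the same read-out, so among these three compounds the higher number goes with (benzyloxycarbonyl)methyl and not with every substituent at this place. No evidence is available on why the two groups differ.

The compounds shown leave open how a carboxylic acid or an amine at this place would read in this assay and whether a chain longer than sec-butyl would stay level with hydrogen. They also leave open whether the defined stereocentre of sec-butyl matters, as only one form of it appears here.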